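The source may hold more compounds than are shown below. What is called first, only, known or untested is meant among the compounds shown, and "the series" means these compounds.

Compound 1 `CCc1nnc(-c2cn3c(C)c(CC)c(OC)nc3n2)o1`: in a functional assay on the whole organism with Rattus norvegicus as the target (a lower number here means that less compound is needed, a higher number that more compound is needed for the effect), compound 1 gives 50 mg/kg.
Compound 2 `CCc1c(OC)nc2nc(-c3nc(C)cs3)cn2c1C`: in this assay compound 2 gives > 50 mg/kg, which is a limit of the assay and not a number.
Compound 3 `CCc1c(OC)nc2nc(-c3nc(C(F)(F)F)cs3)cn2c1C`: in this assay compound 3 gives > 50 mg/kg, again a limit of the assay.

Compound 2 therefore stands at the limit, the same limit at which two of the three values sit (the limit of > 50 mg/kg in this assay, at which 2 of the 3 values shown sit). The steps around it are hard to read: the change from compound 1 to compound 2 gives a number no lower from compound 1 to compound 2 (the limit leaves the size open), and the change from compound 2 to compound 3 gives a step that the two limits leave unreadable from compound 2 to compound 3.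

Compound 4 `CCc1c(OC)nc2nc(-c3nc(C)no3)cn2c1C` is the next compound to be tested. It differs from compound 2 in one place: 3-methyl-1,2,4-oxadiazol-5-yl in place of 4-methyl-1,3-thiazol-2-yl on an aromatic carbon. Among the compounds with values here, of the measured steps, only the one from compound 1 to compound 2 bears on this change, since compound 1 also carries a five-membered ring with three hetero atoms at this place and gives a number, while compound 2 gives only a limit. On that basis compound 4 is expected to return toward the number seen for compound 1, so the step from compound 2 to compound 4 is estimated at a number no higher from compound 2 to compound 4 (the limit leaves the size open), with compound 4 estimated at 50 mg/kg, in a range from 20 mg/kg to 100 mg/kg.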

Compound 4, minimum effective dose: 5 mg/kg
The estimate for compound 4 lay 10-fold (1.00 log units) above the measured number, and the stated range ends above it.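

Within the data shown here, this result is the first readable sign that the group at this place, on an aromatic carbon of the five-membered ring next to the ring nitrogen, can shift the dose needed in this assay: replacing 4-methyl-1,3-thiazol-2-yl with 3-methyl-1,2,4-oxadiazol-5-yl gives an at least 10-fold lower number from compound 2 to compound 4 (1.00 log units; beyond the scatter). That step is open at one end because the value of compound 2 is a limit of the assay, not a number: the limit of > 50 mg/kg in this assay, at which 2 of the 4 values shown sit. The comparison with the other oxadiazole gives a 10-fold lower number from compound 1 to compound 4 (1.00 log units; beyond the scatter), so two rings that each carry three hetero atoms are not interchangeable here, and the hetero atom count alone does not settle the result.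

The step between compound 1 and compound 4 changes the arrangement of the ring atoms and swaps ethyl for methyl at once, so the compounds shown cannot assign the difference to either change, and they give no measured cause for it. On these data alone, it also remains open whether the 3-methyl-1,2,4-oxadiazol-5-yl group would hold this dose if its methyl were replaced by a longer chain such as propyl, by an amine or by a carboxylic acid.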